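An Acylsulfonamide in Place of the Propanoic Acid

This account rests on a few compounds, and the source may have more. Where it says the series, first, only, none or still open, it means among the compounds named here.

Compound 1, `CC(C)c1onc(-c2c(Cl)cccc2Cl)c1COc1ccc(N(C)C(=O)c2cccc(C(=O)O)c2)c(C(F)(F)F)n1`, gives 571 nM in a functional assay on HEK293 cells for agonist activity at Bile acid receptor (Homo sapiens); on this read-out lower numbers stand for an effect already at smaller amounts and higher numbers for an effect only at larger amounts of compound.
Compound 2, `CC(C)c1onc(-c2c(Cl)cccc2Cl)c1COc1ccc(N(C)Cc2ccc(CCC(=O)O)cc2)c(C(F)(F)F)n1`, gives 35 nM in this assay.
Compound 3, `CC(C)c1onc(-c2c(Cl)cccc2Cl)c1COc1ccc(N(C)Cc2cccc(C(=O)O)c2)c(C(F)(F)F)n1`, gives 80 nM in this assay.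

Compound 2 has the lowest number of the three, ahead of compound 3 by a 2.3-fold higher number from compound 2 to compound 3 (0.36 log units; beyond the scatter) and of compound 1 by a 16-fold lower number from compound 1 to compound 2 (1.21 log units; beyond the scatter). Compound 4, `CC(C)c1onc(-c2c(Cl)cccc2Cl)c1COc1ccc(N(C)Cc2ccc(C(=O)NS(C)(=O)=O)cc2)c(C(F)(F)F)n1`, differs from compound 2 by (methylsulfonyl)carbamoyl in place of 2-carboxyethyl on an aromatic carbon. For the measured compounds named here, no measured step touches this change directly; the closest is a 2.3-fold higher number from compound 2 to compound 3 (0.36 log units; beyond the scatter), a modest rise when the 2-carboxyethyl chain is exchanged for a carboxyl on the ring. A rise of similar, modest size in this assay is therefore expected, a 2.0-fold higher number from compound 2 to compound 4 (0.30 log units; within the scatter). Compound 4 is estimated at 70 nM, with a range from 18 nM to 280 nM.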

Compound 4, half-maximal effective concentration: 221 nM
For compound 4 the middle estimate is 3.2-fold (0.50 log units) below the measured one; the measured number falls inside the stated range.
By their numbers in this assay, from the lowest: compound 2; then compound 3; then compound 4; then compound 1.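

On the aromatic carbon para to a large group, (methylsulfonyl)carbamoyl in place of 2-carboxyethyl gives a 6.3-fold higher number from compound 2 to compound 4 (0.80 log units; beyond the scatter) in this assay. This is the first step shown at this position that keeps the para arrangement and swaps the acid-bearing chain for a group with more hydrogen-bond acceptors, and its rise lies beyond the scatter. Nothing given here accounts for the rise.

The compounds shown leave open how a carboxylic acid attached directly at this same aromatic carbon would read out. They also leave open whether (methylsulfonyl)carbamoyl at the end of a longer chain would restore the lower number.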